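Changing the aromatic group of compound 2

This account rests on a few compounds, and the source may have more. Where it says the series, first, only, none or still open, it means among the compounds named here.

Compound 1 `COc1ccccc1-n1cc(CN2C(=O)C[C@@H]3CC[C@@]2(C)C3(C)C)nn1`: 120 nM
Compound 2 `Cc1ccccc1-n1cc(CN2C(=O)C[C@@H]3CC[C@@]2(C)C3(C)C)nn1`: 250 nM

Both numbers come from a functional assay on PANC-1 cells (Homo sapiens) for inhibition, read by MTT assay, with a stated time of 24 h; a lower number here means a stronger inhibitor, a higher number a weaker inhibitor. Of the two, compound 2 has the higher number, which makes it the weaker inhibitor of the pair. The next compound to be tested is compound 3 `CC1(C)[C@H]2CC[C@]1(C)N(Cc1cn(-c3cccc(Br)c3)nn1)C(=O)C2`. It keeps the shared core and changes one group, with 3-bromophenyl in place of 2-methylphenyl on an aromatic nitrogen.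

Going by the values given here, only one measured step bears on this change. It put methyl in place of methoxy on an aromatic carbon of the same aromatic group, and it was modest: a 2.1-fold higher number from compound 1 to compound 2 (0.32 log units; beyond the scatter). Among the compounds with values here, no measured compound carries a bromine, so the data give no direction for this swap. A shift of similar modest size is therefore expected, and it could go either way. The central estimate is a small step, and the expected step is a 1.3-fold lower number from compound 2 to compound 3 (0.10 log units; within the scatter). Compound 3 is estimated at 200 nM, with an expected range from 70 nM to 600 nM.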

Compound 3, half-maximal inhibitory concentration: 90 nM
Compound 3: the middle estimate sits 2.2-fold (0.35 log units) above what was measured; measured number inside the range.
By their numbers in this assay, from the lowest: compounds 3 and 1 (each within the scatter of the next); then compound 2.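

In this assay, the aromatic group on the triazole-type nitrogen position can carry a bromine without any loss: 3-bromophenyl in place of 2-methylphenyl gives a 2.8-fold lower number from compound 2 to compound 3 (0.44 log units; beyond the scatter). Set against the best earlier compound, the same group gives a 1.3-fold lower number from compound 1 to compound 3 (0.12 log units; within the scatter), so 3-bromophenyl and 2-methoxyphenyl cannot be told apart here, and this position tolerates two quite different groups at about the same level, while 2-methylphenyl remains the one that stands apart from both. Nothing measured here explains why these groups differ in this way.

The step from compound 2 to compound 3 changes two things at once, the kind of group on the phenyl ring and the number in its name, so the shift cannot be assigned to either one alone; a 2-bromophenyl or a 3-methylphenyl group would be needed to separate them. From the compounds shown here alone, how this position would respond to a 3-chlorophenyl group, a 3-methoxyphenyl group or an amine on the phenyl ring also remains open.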